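Adding a chloro to compound 3: toxicity expected to stay low

The source may report more compounds than this note shows. Statements on the series, on what has been measured and on what is new or still open speak of the compounds shown alone.

Compound 3 `CCOc1ccc2c(c1)OC(c1ccccc1)C(c1ccccc1)C2=O` shares its core with two measured relatives. In an ADME assay on PBMC cells (Homo sapiens) for cytotoxicity, read by MTT assay, with a stated time of 5 days (on this read-out lower numbers stand for higher toxicity in this test and higher numbers for lower toxicity in this test), compound 3 gives > 2500000 nM, which is a limit of the assay and not a number. Compound 1 `COc1ccc2c(c1)OC(c1ccc([N+](=O)[O-])cc1)C(c1ccccc1)C2=O` carries a nitro group on one of its phenyl rings and gives 595000 nM in this assay. Compound 2 `COc1ccc2c(c1)OC(c1ccc(Cl)cc1)C(c1ccccc1)C2=O` carries a chloro where compound 1 carries the nitro. In this assay compound 2 gives > 2500000 nM, again a limit and not a number. The step of an at least 4.2-fold higher number from compound 1 to compound 2 (0.62 log units; beyond the scatter) shows that swapping nitro for chloro moved the reading up to the ceiling of the test, namely (the limit of > 2500000 nM in this assay, at which 2 of the 3 values shown sit).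

Compound 4 `CCOc1ccc2c(c1)OC(c1ccc(Cl)cc1)C(c1ccccc1)C2=O` differs from compound 3 by chloro in place of hydrogen on an aromatic carbon. Within the data shown here, no measured step adds a chloro to a bare phenyl; the only measured step involving a chloro, an at least 4.2-fold higher number from compound 1 to compound 2 (0.62 log units; beyond the scatter), replaces a nitro and ends at the limit, and compound 2, which already bears that chloro, also sits at the limit. Compound 4 is therefore expected to remain at the limit, with an expected step of a number no higher from compound 3 to compound 4 (the limit leaves the size open) that amounts to none beyond the scatter. The estimate for compound 4 is 2500000 nM, between 1000000 nM and 5000000 nM, most likely reported again only as a limit.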

Compound 4, half-maximal cytotoxic concentration: > 2500000 nM
Compound 4 gave a limit, no number (the forecaster's own chance of this, stated with the estimate: 80%); the middle value lies on the limit itself.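

The steps from compound 3 to compound 4 and from compound 2 to compound 4 cannot be read, for all three compounds stand at the same limit of the test, not at numbers: the limit of > 2500000 nM in this assay, at which 3 of the 4 values shown sit. What the added chloro or the added methyl changes in this assay stays open, since any difference among these three compounds lies beyond that limit.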